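Trifluoromethoxy in Place of Bromo: Expected Cytotoxicity

The source may hold more compounds than are shown below. What is called first, only, known or untested is meant among the compounds shown, and "the series" means these compounds.

For the measured compounds named here, in an ADME assay on HeLa cells (Homo sapiens) for cytotoxicity, read by sulforhodamine B assay, with a stated time of 48 h, tested at 10 uM (a lower number here means less inhibition, a higher number more inhibition at the concentration tested (going by the name of the read-out)), compound 2 `COc1nc2ccc(Br)cc2cc1C(c1ccccc1)n1cc(-c2ccc(Br)cc2)nn1` gives 6.92%, one of only two numbers so far; compound 1 `CCCCc1cn(C(c2ccccc2)c2cc3cc(Br)ccc3nc2OC)nn1` gives -2.87%, and the step of a number 9.8 percentage points higher from compound 1 to compound 2 (within the scatter) is within the scatter. Compound 3 `COc1nc2ccc(Br)cc2cc1C(c1ccccc1)n1cc(-c2ccc(OC(F)(F)F)cc2)nn1` differs from compound 2 by trifluoromethoxy in place of bromo on an aromatic carbon. Going by the values given here, the single measured step, a change on the same aromatic carbon, stayed within the scatter, so the expected step of a number 1.9 percentage points lower from compound 2 to compound 3 (within the scatter) in this assay is likewise none beyond the scatter. Compound 3 is therefore estimated at 5%, with a range from -10% to 20%.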

Compound 3, a percentage reported as inhibition, at one concentration (the size of the read-out at that concentration, not a potency): -2.24%
Compound 3: middle estimate off by 7.2 percentage points, on the high side; the range from low to high includes it.
By their numbers in this assay, from the lowest: compounds 1, 3 and 2 (each within the scatter of the next).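

In this assay, trifluoromethoxy in place of bromo, para to a large group, gives a number 9.2 percentage points lower from compound 2 to compound 3 (within the scatter), so this position has now taken two different substituents on the phenyl ring without a step beyond the scatter. 4-(Trifluoromethoxy)phenyl in place of butyl gives a number 0.6 percentage points higher from compound 1 to compound 3 (within the scatter), and thus none of the three compounds stands apart from another. No evidence is available to explain these readings. As far as these compounds go, whether an amine or a carboxylic acid at this position would give a step beyond the scatter remains open.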